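This account rests on a few compounds, and the source may have more. Where it says the series, first, only, none or still open, it means among the compounds named here.

Compound 1 `COc1ccc(/C=C/C(=O)c2c(C)cc(O)c(C(=O)/C=C/c3ccc(OC)cc3)c2-c2ccc(OCc3ccccc3)cc2)cc1` gives 28000 nM in a functional assay on HeLa cells (Homo sapiens) for cytotoxicity, read by MTT assay, with a stated time of 24 h; on this read-out lower numbers stand for stronger inhibition and higher numbers for weaker inhibition. Compound 2 `COc1ccc(/C=C/C(=O)c2c(C)cc(O)c(C(=O)/C=C/c3ccc(OC)cc3)c2-c2ccc(Br)cc2)cc1` is reported in this assay only as "not active" (no number reported), with no number attached, so its standing against compound 1 cannot be fixed. Compound 3 `COc1ccc(/C=C/C(=O)c2c(C)cc(O)c(C(=O)/C=C/c3ccc(OC)cc3)c2-c2ccccc2)cc1` carries hydrogen in place of bromo on an aromatic carbon. With no number for compound 2, the size of this step in this assay cannot be gauged; both measured compounds show weak or no inhibition, and compound 3 is expected to remain in that weak region rather than move far in either direction. Compound 3 is estimated at 40000 nM, within 15000 nM to 120000 nM, with a real chance that only a limit is reported.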

Compound 3, half-maximal inhibitory concentration: "not active" (no number reported)
The entry for compound 3 holds no number, and the estimate cannot be compared.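

Compound 2 and compound 3 both lack a number in this assay, so no step can be read between them. The compounds shown leave open how large the change from 4-bromophenyl to phenyl is. No supporting evidence bears on this result.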